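From trifluoromethyl to chloro on an aromatic ring

The compounds below may be only part of what the source reports. "The series", "measured", "known", "first", "only" and "open" are said of these compounds alone.

- Compound 1 `N#Cc1ccc(O[C@H]2CN(S(=O)(=O)c3ccc(C(F)(F)F)cc3)C[C@@]2(O)CO)cc1F`: 180 L/kg
- Compound 2 `N#Cc1ccc(O[C@H]2CN(S(=O)(=O)c3ccc(Cl)cc3Cl)C[C@@]2(O)CN)cc1F`: 210 L/kg
- Compound 3 `N#Cc1ccc(O[C@H]2CN(S(=O)(=O)c3ccc(Cl)cc3Cl)C[C@]2(O)CO)cc1F`: 330 L/kg

These three compounds were all tested in an ADME assay on the whole organism (Rattus norvegicus, strain Sprague-Dawley) for pharmacokinetics, read by LC-MS, with a stated time of 30 min (a higher number here means that more of the compound sits outside the plasma, a lower number that more of the compound stays in the plasma), and their values lie close together. Compound 1 gives 180 L/kg, and the other two values fall within the usual scatter of that number, so the data cannot separate compound 1 from either of them.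

The next compound to be measured is compound 4 `N#Cc1ccc(O[C@H]2CN(S(=O)(=O)c3ccc(Cl)cc3)C[C@@]2(O)CO)cc1F`. It keeps the core of compound 1 and changes a single group: chloro in place of trifluoromethyl on an aromatic carbon.

Within the data shown here, no two measured compounds differ in only one place, so the data hold no direct measure of this swap. Among the measured compounds shown here, the only guide is the spread of the measured values. With compound 2 at 210 L/kg and compound 3 at 330 L/kg, that spread stays inside the scatter of compound 1, so no step beyond the scatter is expected in this assay. The expected change is a 1.2-fold higher number from compound 1 to compound 4 (0.09 log units; within the scatter), a step inside the scatter. For compound 4 the estimated value is 220 L/kg, with an expected range from 120 L/kg to 400 L/kg.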

Compound 4, volume of distribution at steady state: 170 L/kg
For compound 4 the middle estimate is 1.3-fold (0.11 log units) above the measured one, within the range that was stated.
By their numbers in this assay, from the lowest: compounds 4, 1, 2 and 3 (each within the scatter of the next).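

Among these compounds, compounds 1 and 4 are the first pair here that differ in one place only, so chloro in place of trifluoromethyl, on an aromatic carbon para to a large group, can now be read directly in this assay. Among the compounds shown here, the step is a 1.1-fold lower number from compound 1 to compound 4 (0.02 log units; within the scatter), so within this pair the two groups cannot be told apart by this read-out, something the earlier compounds, which differ from compound 1 in more than one place, could not show. Nothing measured here offers an explanation for this result.

From the compounds shown here alone, it remains open whether this position would tolerate groups of other kinds just as quietly, such as a methoxy group or a carboxylic acid in place of chloro or trifluoromethyl. It is also unknown whether the same swap would read the same way on a core carrying different groups elsewhere, since this single pair speaks only for the core of compound 1.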